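The source may report more compounds than this note shows. Statements on the series, on what has been measured and on what is new or still open speak of the compounds shown alone.

Compound 1 `O=S(=O)(NCC1CCN(CCCc2c[nH]c3ccc(-n4cnnc4)cc23)CC1)c1ccccc1` is measured in an assay on CHO cells for displacement of a labelled ligand from 5-hydroxytryptamine receptor 1B (Homo sapiens) (a lower number here means a stronger inhibitor, a higher number a weaker inhibitor), where compound 1 gives 60 nM. Among the three compounds measured in this assay this is the second highest number. Compound 2 `c1ccc(CNCC2CCN(CCCc3c[nH]c4ccc(-n5cnnc5)cc34)CC2)cc1` gives 28 nM in this assay, and the step of a 2.1-fold lower number from compound 1 to compound 2 (0.33 log units; beyond the scatter) is beyond the scatter. Compound 3 `CN(Cc1cccs1)C1CCN(CCCc2c[nH]c3ccc(-n4cnnc4)cc23)CC1` gives 140 nM in this assay; the step of a 2.3-fold higher number from compound 1 to compound 3 (0.37 log units; beyond the scatter) and the step of a 5.0-fold higher number from compound 2 to compound 3 (0.70 log units; beyond the scatter) are both beyond the scatter, so compound 3 has the highest number of the three.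

The next compound is compound 4 `CN(Cc1ccsc1)C1CCN(CCCc2c[nH]c3ccc(-n4cnnc4)cc23)CC1`. Relative to compound 1 the change is methyl((thiophen-3-yl)methyl)amino in place of ((phenylsulfonyl)amino)methyl on a saturated ring carbon. For the measured compounds named here, the measured step that bears most directly on this is the one to compound 3, where the same leaving group was replaced by methyl((thiophen-2-yl)methyl)amino and the number rose modestly, as a 2.3-fold higher number from compound 1 to compound 3 (0.37 log units; beyond the scatter) shows. Going by the values given here, compound 4 differs from compound 3 only in the thiophen-3-yl attachment of the same group, and no measured pair separates these two attachments, so a comparable outcome is assumed. A modest rise in this assay is therefore expected for compound 4, with the step estimated as a 2.2-fold higher number from compound 1 to compound 4 (0.34 log units; beyond the scatter). The value expected for compound 4 in this assay is 130 nM, within a range from 55 nM to 310 nM.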

Compound 4, half-maximal inhibitory concentration: 35 nM
Beside the measured number, compound 4's estimate is 3.7-fold (0.57 log units) above it; the whole stated range lies above it.
By their numbers in this assay, from the lowest: compounds 2, 4 and 1 (each within the scatter of the next, the first and the last beyond it); then compound 3.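

In this assay, for the compounds shown here, the attachment of the thiophene proves to count at this position: the first measured pair to separate the two attachments gives a 4.0-fold lower number from compound 3 to compound 4 (0.60 log units; beyond the scatter), for thiophen-3-yl in place of thiophen-2-yl on a saturated chain carbon bound to an amine nitrogen. Methyl((thiophen-3-yl)methyl)amino on the saturated ring carbon cannot be told apart from the groups of the other two compounds, with a 1.7-fold lower number from compound 1 to compound 4 (0.23 log units; within the scatter) and a 1.3-fold higher number from compound 2 to compound 4 (0.10 log units; within the scatter), so among these compounds the higher number of compound 3 goes with the thiophen-2-yl attachment and not with every exchange of the original group. Nothing available on these compounds accounts for the gap between the two attachments.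

On these data alone, whether the gap is particular to thiophene remains open, as a furan-3-yl or furan-2-yl pair, or a pyridin-3-yl and pyridin-2-yl pair, on the same methylamino group would test it. Also open, as far as these compounds go, is the part played by the methyl on the amine nitrogen, which a secondary amine carrying the same thiophen-3-ylmethyl group would address, and by the direct link to the ring carbon, which a methylene spacer of the kind in compound 2 would address.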